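A few compounds are considered here, and "the series" means these few. Any claim that something is new, unique, unknown or untested is made for them only; others in the source may bear on it.

- Compound 1 `CNc1nc(NC2(C#N)CCCCC2)nc(-n2cccn2)n1`: 103 mL/min/kg
- Compound 2 `CNc1nc(NC2(C#N)CCCCC2)nc(SC)n1`: 579 mL/min/kg
- Compound 3 `CNc1nc(NC2(C#N)CCCCC2)nc(C2CC2)n1`: not yet measured

Among the compounds with values here, in an ADME assay on microsomes from liver (Rattus norvegicus) for metabolic stability (on this read-out higher numbers stand for fast clearance and lower numbers for slow clearance), compound 2 gives 579 mL/min/kg, the higher of the two numbers so far. Compound 3 changes one group on the shared core: cyclopropyl in place of methylsulfanyl on an aromatic carbon. In words, it carries cyclopropyl in place of methylsulfanyl on an aromatic carbon. Within the data shown here, only one measured step involves this same place, a 5.6-fold higher number from compound 1 to compound 2 (0.75 log units; beyond the scatter), where methylsulfanyl stands in place of 1H-pyrazol-1-yl. On these data alone, it shows that changing the group here can move the number beyond the scatter, but cyclopropyl itself is untested. With compound 1 at 103 mL/min/kg and compound 2 at 579 mL/min/kg, a value between the two is the cautious expectation. The expected change is a 2.1-fold lower number from compound 2 to compound 3 (0.32 log units; beyond the scatter), a modest fall that may not clear the scatter. Compound 3 is estimated at 280 mL/min/kg, within an expected range of 110 mL/min/kg to 650 mL/min/kg.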

Compound 3, clearance: 276 mL/min/kg
For compound 3 the middle estimate is 1.0-fold (0.01 log units) above the measured one; the range from low to high includes it.
By their numbers in this assay, from the lowest: compound 1; then compound 3; then compound 2.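

In this assay this position now has three groups to compare, and cyclopropyl in place of methylsulfanyl gives a 2.1-fold lower number from compound 2 to compound 3 (0.32 log units; beyond the scatter). Cyclopropyl in place of 1H-pyrazol-1-yl gives a 2.7-fold higher number from compound 1 to compound 3 (0.43 log units; beyond the scatter), so cyclopropyl stands apart from both other groups, with the number for compound 3 lying between those for compound 1 and compound 2. The data offer no explanation of why these three groups rank as they do.

Open, on these data alone, is where other groups at this position would fall, such as a methoxy group, a dimethylamino group or a longer chain like n-propyl, and whether any would give a number lower than that of compound 1. Also open, as far as these compounds go, is whether this order would hold if the methylamino group or the other substituent on the shared core were changed.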